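A Nitro Group on a Weak Growth Inhibitor

The source may hold more compounds than are shown below. What is called first, only, known or untested is meant among the compounds shown, and "the series" means these compounds.

In a functional assay on K562 cells (Homo sapiens) for inhibition, read by sulforhodamine B assay, with a stated time of 48 h (a higher number here means a weaker inhibitor of growth, a lower number a stronger inhibitor of growth), compound 1 `CC(C)(C)NCc1c(C(=O)O)nn(-c2ccccc2)c1-c1ccc(Cl)cc1` gives 364000 nM. Compound 2 `CC(C)(C)NCc1c(C(=O)O)nn(-c2ccccc2)c1-c1ccccc1` reads > 716000 nM, and this is a limit of the assay, not a number. Compound 3 `CC(C)(C)NCc1c(C(=O)O)nn(-c2ccccc2)c1-c1ccc([N+](=O)[O-])cc1` differs from compound 2 by nitro in place of hydrogen on an aromatic carbon, para to a large group, which turns phenyl into 4-nitrophenyl. Within the data shown here, only one measured step bears on this change: an at least 1.9-fold higher number from compound 1 to compound 2 (0.29 log units; that floor lies within the scatter), for hydrogen in place of chloro on an aromatic carbon. Read in reverse, it is the sole measured case of a group replacing that hydrogen, and it sets only a floor. On the evidence of compound 1 at 364000 nM, a modest step towards a lower number is expected in this assay. Compound 3 could also end at a limit of the assay. The estimated change is an at least 1.7-fold lower number from compound 2 to compound 3 (0.23 log units; that floor lies within the scatter). For compound 3 the expected value is 420000 nM, with an estimated range of 170000 nM to 800000 nM.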

Compound 3, concentration for 50% growth inhibition: > 634000 nM
Compound 3: only a limit was reported; the forecaster's own chance of this, stated with the estimate: 35%; middle value at least 1.5-fold (0.17 log units) away from the limit.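

In this assay, compound 3 reads > 634000 nM, which is a limit of the assay and not a number. The step between compound 2 and compound 3 therefore cannot be read, so nitro in place of hydrogen, on this aromatic carbon para to a large group, has no measurable size here. Among these compounds, the one readable step is an at least 1.7-fold higher number from compound 1 to compound 3 (0.24 log units; that floor lies within the scatter), for nitro in place of chloro, which leaves compound 1 as the only one of the three compounds with a number rather than a limit.

From the compounds shown here alone, whether nitro changes growth inhibition relative to hydrogen or chloro remains open. So does whether a methoxy group or an amine at the same place would give a number, or would again end at a limit.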